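The source may report more compounds than this note shows. Statements on the series, on what has been measured and on what is new or still open speak of the compounds shown alone.

Compound 1 `COc1cccc(N2CCN(C(=O)CN3C(=O)CC(C)(c4ccccc4)C3=O)CC2)c1` and compound 2 `CC1(c2ccccc2)CC(=O)N(CC(=O)N2CCN(c3ncccn3)CC2)C1=O` share a core and differ only in the group carried on the amine nitrogen in the ring. In a functional assay on the whole organism (strain CD-1) with Mus musculus as the target, with a stated time of 0.5 h (a higher number here means that more compound is needed for the effect, a lower number that less compound is needed), compound 1 gives 100 mg/kg. In this assay compound 2 is reported as "not active" (no number reported), so compound 2 stands without a number of its own at any dose tested. Compound 3 `CC1(c2ccccc2)CC(=O)N(CC(=O)N2CCN(c3cccc(C(F)(F)F)c3)CC2)C1=O` has not yet been measured. The change from compound 2 to compound 3 is 3-(trifluoromethyl)phenyl in place of pyrimidin-2-yl on an amine nitrogen in a ring. Within the data shown here, since no measured step connects compound 2 to another compound, the size of the step to compound 3 can only be guessed; an aryl group in place of the heteroaryl is expected to move compound 3 back toward the behaviour of compound 1, which gives 100 mg/kg, so the direction expected is toward less compound being needed. Compound 3 is estimated at 100 mg/kg, with a likely range from 30 mg/kg to 300 mg/kg.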

Compound 3, minimum effective dose: "not active" (no number reported)
No number was reported for compound 3; the estimate stays without a comparison.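

In this assay, among these compounds, compound 2 and compound 3 are both reported as not active, and no step between them can be read. Nothing available bears on this result. The compounds shown leave open how far either group on the amine nitrogen falls short of an effect.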